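From ethyl to bromo on the aromatic ring

The source may report more compounds than this note shows. Statements on the series, on what has been measured and on what is new or still open speak of the compounds shown alone.

Compound 1 `O=C1C=CC(OCC(F)(F)F)N1c1cc(Cl)cc(Cl)c1` gives 2430 nM in a functional assay on MDA-MB-231 cells (Homo sapiens) for inhibition; on this read-out higher numbers stand for weaker inhibition and lower numbers for stronger inhibition.
Compound 2 `CCc1ccc(N2C(=O)C=CC2OCC(F)(F)F)cc1` gives 7840 nM in this assay.

Of the two numbers, compound 2 stands highest; its nearest neighbour, compound 1, shows a number lower by a margin beyond the scatter. Among the measured compounds shown here, no step between two measured compounds that differ in one place exists in this set. Compound 3 `O=C1C=CC(OCC(F)(F)F)N1c1ccc(Br)cc1` has not yet been measured in this assay. It differs from compound 2 in one way: bromo in place of ethyl on an aromatic carbon. For the measured compounds named here, the change cannot be anchored to a measured step; the only guide is that compound 1, which carries chloro groups, gives 2430 nM. On that basis a step of modest size toward a lower number is expected, a 2.0-fold lower number from compound 2 to compound 3 (0.29 log units; within the scatter), though a step of no size beyond the scatter would not surprise. Compound 3 is accordingly estimated at 4000 nM, with a range from 1500 nM to 12000 nM.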

Compound 3, half-maximal inhibitory concentration: 7570 nM
Beside the measured number, compound 3's estimate is 1.9-fold (0.28 log units) below it; the range from low to high includes it.
By their numbers in this assay, from the lowest: compound 1; then compounds 3 and 2 (each within the scatter of the next).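

In this assay, bromo in place of ethyl on an aromatic carbon, para to a large group, gives a 1.0-fold lower number from compound 2 to compound 3 (0.02 log units; within the scatter) and so leaves the read-out unchanged within the scatter. Among the compounds shown here, this is the first step that can be read at this position, and it shows that one bromine atom and the two carbons of ethyl cannot be told apart here, so this swap offers no handle on the read-out. Nothing measured here explains why the two groups read alike.

On these data alone, whether an amine, a carboxylic acid or a longer chain at this same position would move the number remains open. So does how a single chloro there would read, which would give a one-place link between these compounds and the chloro pattern of compound 1.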